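The compounds below may be only part of what the source reports. "The series", "measured", "known", "first", "only" and "open" are said of these compounds alone.

Compound 1, `Nc1nc(Cl)c2ncn(Cc3ccc(CCl)cc3)c2n1`, gives 63100 nM in a functional assay on SK-MEL-5 cells (Homo sapiens) for cytotoxicity, read by sulforhodamine B assay, with a stated time of 48 h; on this read-out higher numbers stand for lower toxicity in this test and lower numbers for higher toxicity in this test.
Compound 2, `ClCc1cccc(Cn2cnc3c(Cl)nc(Cl)nc32)c1`, gives 5880 nM in this assay.
Compound 3, `ClCc1ccc(Cn2cnc3c(Cl)nc(Cl)nc32)cc1`, gives 44700 nM in this assay.

Compound 2 has the lowest number of the three; its nearest neighbour is compound 3, and compound 1 lies furthest from it, both gaps beyond the scatter. Compound 3 and compound 1 share a core and differ by amino in place of chloro on an aromatic carbon, and this change made a 1.4-fold higher number from compound 3 to compound 1 (0.15 log units; within the scatter).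

Compound 4, `Nc1nc(Cl)c2ncn(Cc3cccc(CCl)c3)c2n1`, has not yet been tested in this assay. It differs from compound 2 by amino in place of chloro on an aromatic carbon. The surroundings of the change are the same in both pairs, so this is the same change as from compound 3 to compound 1. Compound 2 and compound 3 have the same atoms joined differently; the difference between the two cores is not broken down here.

In this assay, compound 4 is expected to show a 1.4-fold higher number from compound 2 to compound 4 (0.14 log units; within the scatter), resting on the step from compound 3 to compound 1 and on compound 2 at 5880 nM. Compound 4 is therefore estimated at 8200 nM, between 4000 nM and 17000 nM.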

Compound 4, concentration lethal to 50% of the cells: 51300 nM
Compound 4: the middle estimate sits 6.3-fold (0.80 log units) below what was measured; measured number outside the range, above it.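

In this assay, amino in place of chloro on an aromatic carbon gave an 8.7-fold higher number from compound 2 to compound 4 (0.94 log units; beyond the scatter), so on the core of compound 2 the change goes with a clearly higher number and thus with lower toxicity in this test. Set beside the earlier step, the same change did not carry over in size from one core to the other: the same change on two cores in this assay, a 1.4-fold higher number (0.15 log units; within the scatter) from compound 3 to compound 1 and an 8.7-fold higher number (0.94 log units; beyond the scatter) from compound 2 to compound 4, 6.2-fold (0.79 log units) apart, beyond the scatter of two such steps. Among the compounds shown here, this shows that a step read on one of these cores cannot simply be transferred to the other, but with only two pairs it does not show what in the cores sets the gap, or how the change would behave on any further core.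

The compounds shown hold only amino or chloro on the carbon between two ring nitrogen atoms, so it stays open whether a methylamino or a methoxy group there would give a large step or a small one on the two cores. Also open, from the compounds shown here alone, is what a hydroxymethyl group in place of the chloromethyl group would do in either pair.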